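A few compounds are considered here, and "the series" means these few. Any claim that something is new, unique, unknown or untested is made for them only; others in the source may bear on it.

Measured so far in a functional assay on SMMC-7721 cells (Homo sapiens) for inhibition, read by CCK-8 assay, with a stated time of 72 h, tested at 8 uM; a higher number here means more inhibition of growth at the concentration tested, a lower number less inhibition of growth:
- compound 1 `Nc1ccccc1NC(=O)c1ccc(CSc2cccc(F)c2)cc1` gives 83%
- compound 2 `Cc1ccc(SCc2ccc(C(=O)Nc3ccccc3N)cc2)cc1` gives 82.7%
- compound 3 `Nc1ccccc1NC(=O)c1ccc(CSc2nccc(C(F)(F)F)n2)cc1` gives 80.6%

Compound 2 at 82.7% stands within the scatter of both compound 1 and compound 3, so these three show no separation so far. The next step leads to compound 4 `Nc1ccccc1NC(=O)c1ccc(CSc2ccc(F)cc2)cc1` through fluoro in place of methyl on an aromatic carbon (fluoro in place of methyl on an aromatic carbon, para to a large group). For the measured compounds named here, the one measured step that bears on it is a number 0.3 percentage points lower from compound 1 to compound 2 (within the scatter) (4-methylphenyl in place of 3-fluorophenyl on a sulfur), and from it no step beyond the scatter is expected here. Going by the values given here, no measured pair shows this exact change. The estimated step is a number 0.7 percentage points lower from compound 2 to compound 4 (within the scatter) with no clear direction expected. For compound 4 the expected value is 82% with an estimated range from 75% to 89% in this assay at this concentration.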

Compound 4, percent growth inhibition at one concentration: 81.9%
The estimate for compound 4 lay 0.1 percentage points above the measured number; measured number inside the range.
By their numbers in this assay, from the lowest: compounds 3, 4, 2 and 1 (each within the scatter of the next).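

Fluoro in place of methyl on an aromatic carbon, para to a large group, gives a number 0.8 percentage points lower from compound 2 to compound 4 (within the scatter) in this assay, so this exchange at this place does not separate the two compounds. Fluoro on the ring at sulfur also reads the same in both placements, with 4-fluorophenyl in place of 3-fluorophenyl giving a number 1.1 percentage points lower from compound 1 to compound 4 (within the scatter). No supporting data offer an explanation for these results.

Still open, going by these compounds, is whether an amine or a carboxylic acid at this place would give a step beyond the scatter.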